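This account rests on a few compounds, and the source may have more. Where it says the series, first, only, none or still open, it means among the compounds named here.

In a functional assay on MeWo cells (Homo sapiens) for antiproliferative activity (a lower number here means a stronger inhibitor, a higher number a weaker inhibitor), compound 1 `COc1cc(/C=C\Cc2cc(O)c3ccsc3c2)cc(OC)c1OC` gives 68 nM and compound 2 `COc1cc(/C=C\Cc2cc(O)c3ccoc3c2)cc(OC)c1OC` gives 71 nM, so the two lie within the usual scatter of each other and neither can be ranked above the other. Compound 3 `COc1cc(/C=C\Cc2cc(OP(=O)(O)O)c3ccsc3c2)cc(OC)c1OC` carries a single change from compound 1, on an oxygen on an aromatic ring: a group of 4 heavy atoms (3 oxygen, 1 phosphorus; no ring) in place of a hydrogen atom, on an oxygen on an aromatic ring. For the measured compounds named here, no measured pair shows what such a change does, so the expectation in this assay is only a cautious one, of a modest weakening. The expected change is a 1.6-fold higher number from compound 1 to compound 3 (0.21 log units; within the scatter). For compound 3 the estimated value is 110 nM, with an expected range of 40 nM to 450 nM.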

Compound 3, half-maximal inhibitory concentration: 830 nM
The estimate for compound 3 lay 7.5-fold (0.88 log units) below the measured number, outside the stated range (above it).
By their numbers in this assay, from the lowest: compounds 1 and 2 (each within the scatter of the next); then compound 3.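

In this assay, this oxygen on an aromatic ring does not accept the change freely: a group of 4 heavy atoms (3 oxygen, 1 phosphorus; no ring) in place of the hydrogen gives a 12-fold higher number from compound 1 to compound 3 (1.09 log units; beyond the scatter) and so a large loss of antiproliferative strength. The hydrogen on this oxygen therefore cannot be swapped for this group without cost. No measurement here explains the loss.

As far as these compounds go, whether a smaller acetyl group on the same oxygen would cost as much remains open. So does whether an amine in place of the hydroxyl would hold the strength of compound 1.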